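This account rests on a few compounds, and the source may have more. Where it says the series, first, only, none or still open, it means among the compounds named here.

Working notes on the series. Compound 1 `CCOC(=O)c1c(-c2cccc(-c3ccccc3)c2)[nH]c2cc(OC(C)C)ccc2c1=O` and compound 2 `CCOC(=O)c1c(-c2cccc(OC)c2)[nH]c2cc(OC(C)C)ccc2c1=O` share one core and differ by methoxy in place of phenyl on an aromatic carbon. In an ADME assay on HepG2 cells (Homo sapiens) for cytotoxicity, read by luminescence, with a stated time of 72 h (on this read-out lower numbers stand for an effect already at smaller amounts and higher numbers for an effect only at larger amounts of compound), compound 1 gives only a limit, > 21500 nM. In this assay compound 2 likewise gives only a limit, > 21500 nM. The step that the two limits leave unreadable from compound 1 to compound 2 therefore carries no readable size. Compound 3 `CCOC(=O)c1c(-c2cccc(-c3ccccc3)c2)[nH]c2cc(Cl)c(Cl)cc2c1=O` stands on a second core; the difference between the two cores is not broken down here. In this assay compound 3 again gives only a limit, > 21500 nM. Among the measured compounds shown here, every value in hand sits at the limit of > 21500 nM in this assay, at which 3 of the 3 values shown sit, so no compound can be ordered against another. Compound 4 `CCOC(=O)c1c(-c2cccc(OC)c2)[nH]c2cc(Cl)c(Cl)cc2c1=O` is the unmeasured partner of compound 3 and carries the same change, (methoxy in place of phenyl on an aromatic carbon). Because the measured pair leaves a step that the two limits leave unreadable from compound 1 to compound 2 unreadable, the step from compound 3 to compound 4 is expected to be equally flat, a step that the limit leaves unreadable from compound 3 to compound 4, with a limit as the most likely outcome. For compound 4 the expected value in this assay is 40000 nM, with a plausible span from 15000 nM to 150000 nM, and a result again reported only as a limit is anticipated.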

Compound 4, half-maximal effective concentration: > 21500 nM
Compound 4: a limit, no number; the forecaster's own chance of this, stated with the estimate: 85%; the middle value does not contradict the limit.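

In this assay compound 4 gives > 21500 nM, which is a limit and not a number. No step can be read between compound 3 and compound 4, and the series offers no ordering: the limit of > 21500 nM in this assay, at which 4 of the 4 values shown sit. The compounds shown leave open where any of their half-maximal effective concentrations lies, and whether methoxy in place of phenyl changes it.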